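A Small Ester in Place of a Phenylethyl Group

The source may hold more compounds than are shown below. What is called first, only, known or untested is meant among the compounds shown, and "the series" means these compounds.

Compound 1 `C[C@@H](Nc1c(C(=O)NCc2ccc(F)cc2)nc(Br)c2cccnc12)c1ccccc1` was tested in a functional assay on HCT-116 cells (Homo sapiens) for cytotoxicity, read by MTT assay, with a stated time of 72 h; a higher number here means a weaker inhibitor, a lower number a stronger inhibitor. In this assay compound 1 gives > 20000 nM, which is a limit of the assay and not a number, so compound 1 sits at the limit of > 20000 nM in this assay, at which 1 of the 3 values shown sits. Two other compounds sharing the core of compound 1 have numbers: compound 2 `N[C@H]1CC[C@H](Nc2c(C(=O)NCc3ccc(Cl)cc3)nc(Br)c3cccnc23)CC1` gives 4000 nM in this assay, and compound 3 `O=CNCCCCCCNc1nc(C(=O)NCc2ccc(F)cc2)c(O)c2ncccc12` gives 4000 nM in this assay. Compound 4 `COC(=O)CNc1c(C(=O)NCc2ccc(F)cc2)nc(Br)c2cccnc12` differs from compound 1 by (methoxycarbonyl)methyl in place of 1-phenylethyl on a nitrogen on an aromatic ring. For the measured compounds named here, no measured pair of compounds shows this change, so its size can only be expected: a modest gain in potency is estimated, and an at least 1.3-fold lower number from compound 1 to compound 4 (0.12 log units; that floor lies within the scatter) is expected to leave compound 4 still a weak inhibitor. Compound 4 is expected to give 15000 nM, within 4000 nM to 50000 nM.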

Compound 4, half-maximal inhibitory concentration: > 10000 nM
Compound 4: only a limit was reported; the forecaster's own chance of this, stated with the estimate: 45%; the middle value lies beyond the limit too.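

For the compounds shown here, compound 1 and compound 4 each carry only a limit in this assay, and no step between them can be read. The compounds shown leave open whether (methoxycarbonyl)methyl in place of 1-phenylethyl changes potency at all.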